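Triazole-linked sulfonamides: ortho versus para attachment

The compounds below may be only part of what the source reports. "The series", "measured", "known", "first", "only" and "open" are said of these compounds alone.

Measured so far:
Compound 1 `O=c1[nH]cc(S(=O)(=O)Nc2ccccc2-c2cn(-c3ccc(F)cc3)nn2)c(=O)[nH]1`: > 20000 nM, a limit of the assay.
Compound 2 `O=c1[nH]cc(S(=O)(=O)Nc2ccccc2-c2cn(-c3ccccc3Cl)nn2)c(=O)[nH]1`: 6520 nM.
Compound 3 `O=c1[nH]cc(S(=O)(=O)Nc2ccc(-c3cn(-c4ccc(F)cc4)nn3)cc2)c(=O)[nH]1`: > 20000 nM, a limit of the assay.

All values come from a functional assay on SGC-7901 cells (Homo sapiens) for antiproliferative activity, read by MTT assay, with a stated time of 24 h; on this read-out higher numbers stand for weaker inhibition and lower numbers for stronger inhibition. Going by the values given here, the one measured step is 2-chlorophenyl in place of 4-fluorophenyl on an aromatic nitrogen, which gave an at least 3.0-fold lower number from compound 1 to compound 2 (0.48 log units; beyond the scatter). The value of compound 1 sits at the limit of > 20000 nM in this assay, at which 2 of the 3 values shown sit, so that step is known only as a bound. Compound 3 has the same atoms as compound 1, joined differently; the difference between the two cores is not broken down here. Compound 4 `O=c1[nH]cc(S(=O)(=O)Nc2ccc(-c3cn(-c4ccccc4Cl)nn3)cc2)c(=O)[nH]1` is not yet measured; it differs from compound 3 by 2-chlorophenyl in place of 4-fluorophenyl on an aromatic nitrogen, the same change as that made from compound 1 to compound 2, at the same place. Compound 3 also sits at the limit of > 20000 nM in this assay, at which 2 of the 3 values shown sit. For compound 4 the expected step is an at least 1.8-fold lower number from compound 3 to compound 4 (0.25 log units; that floor lies within the scatter), resting on the step of an at least 3.0-fold lower number from compound 1 to compound 2 (0.48 log units; beyond the scatter) on the core of compound 1 and on the limit of > 20000 nM in this assay, at which 2 of the 3 values shown sit, at which compound 3 starts. The estimate for compound 4 in this assay is 11000 nM, within 4000 nM to 20000 nM, with a fair chance that only a limit is reported.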

Compound 4, half-maximal inhibitory concentration: 2680 nM
For compound 4 the middle estimate is 4.1-fold (0.61 log units) above the measured one; the measured number lies below the stated range.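

In this assay, 2-chlorophenyl in place of 4-fluorophenyl on the aromatic nitrogen gives an at least 7.4-fold lower number from compound 3 to compound 4 (0.87 log units; beyond the scatter), so the direction seen on the core of compound 1 carries over to the core of compound 3. The two cores therefore agree in direction, but this does not show that the change has the same size on both: the same change on two cores in this assay, an at least 3.0-fold lower number (0.48 log units; beyond the scatter) from compound 1 to compound 2 and an at least 7.4-fold lower number (0.87 log units; beyond the scatter) from compound 3 to compound 4; the limit leaves it open whether they differ. Going by these compounds, compound 1 and compound 3 each stand at a limit of the assay, so both steps are bounds and their true sizes stay unknown: the limit of > 20000 nM in this assay, at which 2 of the 4 values shown sit.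

The compounds shown leave open whether the step belongs to the chlorine atom or to its place on the phenyl ring, a question that 2-fluorophenyl and 4-chlorophenyl on the same nitrogen would separate. Also open, on these data alone, is whether the direction holds for other groups at that nitrogen, such as a phenyl ring carrying an amine or a carboxylic acid, or on any further core.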